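Adding a third fluorine to a difluorinated aryl ether

This account rests on a few compounds, and the source may have more. Where it says the series, first, only, none or still open, it means among the compounds named here.

Three compounds share a core and differ only in how fluorine is placed on a six-membered aromatic ring of carbon only. Compound 1 `Cc1cc(COc2cccc(F)c2F)nc(-c2ccccn2)n1` gives 398 nM in a functional assay on cells for antagonist activity at Free fatty acid receptor 1 (Homo sapiens), read by TR-FRET and inositol phosphate accumulation, with a stated time of 2 h; a lower number here means a stronger inhibitor, a higher number a weaker inhibitor. Compound 2 `Cc1cc(COc2ccc(F)c(F)c2)nc(-c2ccccn2)n1` gives 501 nM in this assay, a number within the usual scatter of that of compound 1; the difference between the two cores is not broken down here. Compound 3 `Cc1cc(COc2c(F)ccc(F)c2F)nc(-c2ccccn2)n1` gives 1580 nM in this assay.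

Compound 3 is made from compound 1 by one change (fluoro in place of hydrogen on an aromatic carbon), and this change cost potency: a 4.0-fold higher number from compound 1 to compound 3 (0.60 log units; beyond the scatter).

Compound 4 `Cc1cc(COc2cc(F)c(F)c(F)c2)nc(-c2ccccn2)n1`, not yet measured, is made from compound 2 by a change of the same kind (fluoro in place of hydrogen on an aromatic carbon). The surroundings differ: in compound 3 the new fluoro sits ortho to a large group and para to a fluoro group, while in compound 4 it sits ortho to a fluoro group and meta to a large group, with meta to a fluoro group shared.

Within the data shown here, because the one measured example of this kind of change gave a 4.0-fold higher number from compound 1 to compound 3 (0.60 log units; beyond the scatter), a loss of potency is expected for compound 4 too, though the different surroundings leave its size uncertain. The expected step is a 2.5-fold higher number from compound 2 to compound 4 (0.40 log units; beyond the scatter). Compound 4 is estimated at 1250 nM in this assay, expected to lie between 500 nM and 3200 nM.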

Compound 4, half-maximal inhibitory concentration: 398 nM
Compound 4: the middle estimate sits 3.1-fold (0.50 log units) above what was measured; the measured number lies below the stated range.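

The new step is a 1.3-fold lower number from compound 2 to compound 4 (0.10 log units; within the scatter) in this assay, so on this core the added fluoro brings no loss that can be told apart from the ordinary spread of repeated measurements. Swapping a hydrogen for a fluoro therefore does not carry a fixed effect from one core to the other, and the two outcomes really do differ: the same change on two cores in this assay, a 4.0-fold higher number (0.60 log units; beyond the scatter) from compound 1 to compound 3 and a 1.3-fold lower number (0.10 log units; within the scatter) from compound 2 to compound 4, 5.0-fold (0.70 log units) apart, beyond the scatter of two such steps. Among these compounds, this shows that a result from one fluorinated compound cannot simply be transferred to a compound with a different fluorine pattern, but with only one example on each core it does not show which feature of the surroundings sets the outcome, and it gives no rule for other patterns.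

Open, as far as these compounds go, is whether the place of the new fluoro, ortho to a large group in compound 3 and meta to a large group in compound 4, is what separates the two results, or whether the fluorine atoms already on the ring matter more. Also open, from the compounds shown here alone, is how these same ring places would respond to a group other than fluoro, such as a chlorine atom or a methoxy group.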